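Swapping methoxycarbonyl for hydroxy in compound 2

A few compounds are considered here, and "the series" means these few. Any claim that something is new, unique, unknown or untested is made for them only; others in the source may bear on it.

Measured in an ADME assay on MIA PaCa-2 cells (Homo sapiens) for cytotoxicity, read by MTT assay, with a stated time of 72 h; a lower number here means a stronger inhibitor, a higher number a weaker inhibitor:
- compound 1 `COc1cc(C2=C(c3cc(C)c(OC)c(C)c3)C(O)CC2=O)cc(OC)c1OC`: > 100 ug/mL (a limit)
- compound 2 `COC(=O)c1cc(C2=C(c3cc(OC)c(OC)c(OC)c3)C(=O)CC2O[SiH2]C(C)(C)C)ccc1OC`: > 100 ug/mL (a limit)
- compound 3 `CC(=O)OC1C/C(=N/O)C(c2ccccc2)=C1c1ccccc1`: 4.5 ug/mL

Compound 2 stands at the limit of > 100 ug/mL in this assay, at which 2 of the 3 values shown sit. It therefore offers a limit and no number, which leaves any later comparison without a fixed starting point.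

The next compound to be tested is compound 4 `COc1ccc(C2=C(c3cc(OC)c(OC)c(OC)c3)C(=O)CC2O[SiH2]C(C)(C)C)cc1O`. It carries hydroxy in place of methoxycarbonyl on an aromatic carbon. The change sits ortho to a methoxy group and meta to a large group, and it turns 4-methoxy-3-(methoxycarbonyl)phenyl into 3-hydroxy-4-methoxyphenyl.

Among the measured compounds shown here, no two measured compounds differ in one place only, so no measured step shows what this swap does in this assay. Compound 3 does give a number, 4.5 ug/mL, which shows that a compound in this small set can return a value rather than a limit. On that slender basis, the expected change is an at least 6.6-fold lower number from compound 2 to compound 4 (0.82 log units; beyond the scatter), in the direction of stronger inhibition. A second limit would be no surprise. For compound 4 the estimated value is 15 ug/mL, with an expected range from 1 ug/mL to 100 ug/mL.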

Compound 4, half-maximal inhibitory concentration: 55 ug/mL
For compound 4 the middle estimate is 3.7-fold (0.56 log units) below the measured one; the range from low to high includes it.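

In this assay, compound 4 gives a measured number, 55 ug/mL, which shows that a hydroxy group on this aromatic carbon, ortho to a methoxy group, leaves the compound within the range this read-out can put a figure on. Compound 2 offers only a limit and not a number: the limit of > 100 ug/mL in this assay, at which 2 of the 4 values shown sit. The swap of methoxycarbonyl for hydroxy can therefore be stated only as an at least 1.8-fold lower number from compound 2 to compound 4 (0.25 log units; that floor lies within the scatter); the true gap may be wider, but this floor alone does not show a change larger than the ordinary spread of repeat measurements.

The compounds shown leave open whether the gain comes from having hydroxy on this carbon or simply from losing methoxycarbonyl, a question that an amine, a carboxylic acid or a plain hydrogen at the same place would help to settle. Going by these compounds, compound 1 and compound 3 differ from this pair in more than one place, so they cannot answer it, and how far the shared core could go with any other group here remains unknown.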